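The source may report more compounds than this note shows. Statements on the series, on what has been measured and on what is new or still open speak of the compounds shown alone.

In an ADME assay for permeability, using PAMPA, at pH 7.4 (a lower number here means that the compound crosses the layer more slowly, a higher number that the compound crosses the layer faster), compound 2 (`COc1cccc(C(=O)NCCNC(=O)[C@H](CC(=O)NC(C)(C)C)NS(=O)(=O)c2ccc(C)cc2)c1`) gives 159 nm/s, within the scatter of compound 1 (`Cc1ccc(S(=O)(=O)N[C@@H](CC(=O)NC(C)(C)C)C(=O)NCCNC(=O)c2ccccc2)cc1`) at 137 nm/s. Compound 3 (`Cc1ccc(S(=O)(=O)N[C@@H](CC(=O)NC(C)(C)C)C(=O)NCCNC(=O)c2ccccc2F)cc1`) differs from compound 2 as follows: 2-fluorophenyl in place of 3-methoxyphenyl on a carbonyl carbon. Going by the values given here, the one measured step that bears on this group is a 1.2-fold higher number from compound 1 to compound 2 (0.06 log units; within the scatter), for methoxy in place of hydrogen on an aromatic carbon. Among the compounds with values here, no measured step covers fluorine. No change beyond the scatter is therefore expected in this assay, and the estimated step is a 1.1-fold lower number from compound 2 to compound 3 (0.03 log units; within the scatter). For compound 3 the expected value is 150 nm/s, with an estimated range of 85 nm/s to 260 nm/s.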

Compound 3, apparent permeability: 105 nm/s
Estimate against measurement, compound 3: 1.4-fold (0.15 log units) above, within the range that was stated.
By their numbers in this assay, from the lowest: compounds 3, 1 and 2 (each within the scatter of the next).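

Swapping the aromatic group on this carbonyl carbon, 2-fluorophenyl in place of 3-methoxyphenyl, gives a small change in this assay (a 1.5-fold lower number from compound 2 to compound 3 (0.18 log units; within the scatter)). Fluoro in place of hydrogen on an aromatic carbon, a change not covered by the earlier step, is also small (a 1.3-fold lower number from compound 1 to compound 3 (0.12 log units; within the scatter)). Across compound 1, compound 2 and compound 3, this position therefore shows no step beyond the scatter, and no measurement at hand explains the result.

From the compounds shown here alone, whether an amine or a carboxylic acid on this aromatic ring would give a step beyond the scatter remains open. So does whether these small steps would hold with changes elsewhere on the shared core.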